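Exchanging the acetamidophenyl group for a diethylphenyl group

The source may report more compounds than this note shows. Statements on the series, on what has been measured and on what is new or still open speak of the compounds shown alone.

Compound 3 `CC(=O)Nc1ccc(-n2nncc2CN2C(=O)C3(C(C#N)=C(N)Oc4c(N)cc5nc6ccccc6nc5c43)c3ccccc32)cc1` stands at the edge of what a functional assay on MCF7 cells (Homo sapiens) for antiproliferative activity, read by MTT assay, with a stated time of 48 h (a lower number here means a stronger inhibitor, a higher number a weaker inhibitor), can report: in this assay compound 3 gives > 50000 nM, which is a limit rather than a number, as noted by the limit of > 50000 nM in this assay, at which 1 of the 3 values shown sits. Compound 4 `CCc1cccc(CC)c1-n1nncc1CN1C(=O)C2(C(C#N)=C(N)Oc3c(N)cc4nc5ccccc5nc4c32)c2ccccc21` differs from compound 3 in one place: 2,6-diethylphenyl in place of 4-acetamidophenyl on an aromatic nitrogen. For the measured compounds named here, two measured steps bear on this change, both ending at compound 3. Compound 1 `CCc1ccccc1-n1nncc1CN1C(=O)C2(C(C#N)=C(N)Oc3c(N)cc4nc5ccccc5nc4c32)c2ccccc21` gives 24600 nM, and an at least 2.0-fold higher number from compound 1 to compound 3 (0.30 log units; that floor lies within the scatter). Compound 2 `N#CC1=C(N)Oc2c(N)cc3nc4ccccc4nc3c2C12C(=O)N(Cc1cnnn1-c1ccccc1Br)c1ccccc12` gives 30700 nM, and an at least 1.6-fold higher number from compound 2 to compound 3 (0.21 log units; that floor lies within the scatter). Read in reverse, both steps point toward a lower number once the 4-acetamidophenyl group is removed, and the 2,6-diethylphenyl group of compound 4 most resembles the 2-ethylphenyl group of compound 1. Compound 4 is therefore expected to fall back to a measurable value, with an at least 1.9-fold lower number from compound 3 to compound 4 (0.28 log units; that floor lies within the scatter) expected. The estimate for compound 4 is 26000 nM, between 12000 nM and 60000 nM.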

Compound 4, half-maximal inhibitory concentration: > 50000 nM
Compound 4 gave a limit, no number; the forecaster's own chance of this, stated with the estimate: 25%; at least 1.9-fold (0.28 log units) between middle value and limit.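

In this assay, replacing the 4-acetamidophenyl group with 2,6-diethylphenyl did not return a measurable value, and the step between compound 3 and compound 4 cannot be read. A second ethyl group gives an at least 2.0-fold higher number from compound 1 to compound 4 (0.30 log units; that floor lies within the scatter), and the exchange from 2-bromophenyl gives an at least 1.6-fold higher number from compound 2 to compound 4 (0.21 log units; that floor lies within the scatter); both floors lie within the scatter, so neither establishes a change. The limit now applies to two compounds: the limit of > 50000 nM in this assay, at which 2 of the 4 values shown sit.

From the compounds shown here alone, whether a 2,6-dimethylphenyl or a 4-aminophenyl group on this aromatic nitrogen would give a measurable value stays open.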